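Dichlorophenyl sulfonamide step in a weakly active series

The compounds below may be only part of what the source reports. "The series", "measured", "known", "first", "only" and "open" are said of these compounds alone.

Going by the values given here, in a functional assay on HeLa cells (Homo sapiens) for antiproliferative activity, read by MTT assay, with a stated time of 48 h (on this read-out higher numbers stand for weaker inhibition and lower numbers for stronger inhibition), compound 1 `Cn1cc(-c2cnc3ccnc(N)c3c2)cn1` gives 40800 nM, the only numerical reading so far. Compound 2 `Cn1cc(-c2cnc3ccc(NC(=O)c4ccc(F)cc4)nc3c2)cn1` reads > 50000 nM, which is a limit of the assay. Compound 3 `Cc1ccc(S(=O)(=O)Nc2ccc3ncc(-c4cnn(C)c4)cc3n2)cc1` reads > 50000 nM, also a limit and not a number. Compound 3 therefore belongs to the limit of > 50000 nM in this assay, at which 2 of the 3 values shown sit. Compound 4 `Cn1cc(-c2cnc3ccc(NS(=O)(=O)c4ccc(Cl)cc4Cl)nc3c2)cn1` is reached by 2,4-dichlorophenyl in place of 4-methylphenyl on a sulfonyl sulfur. Among the compounds with values here, no measured pair tests such a change. The expected outcome in this assay is a number no higher from compound 3 to compound 4 (the limit leaves the size open), with no shift beyond the scatter in either direction. Compound 4 is estimated at 50000 nM, with an expected range of 25000 nM to 100000 nM.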

Compound 4, half-maximal inhibitory concentration: > 50000 nM
Compound 4: only a limit was reported (the forecaster's own chance of this, stated with the estimate: 70%); the middle value lies on the limit itself.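

Compound 3 and compound 4 both stand as limits, so no step between them can be read: the limit of > 50000 nM in this assay, at which 3 of the 4 values shown sit.

As far as these compounds go, whether 2,4-dichlorophenyl in place of 4-methylphenyl on a sulfonyl sulfur changes the reading in this assay stays open.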